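From Phenyl to Hydroxy: What Compound 3 Might Show

A few compounds are considered here, and "the series" means these few. Any claim that something is new, unique, unknown or untested is made for them only; others in the source may bear on it.

Measured so far:
compound 1, `COc1ccc(C(=O)c2ccc(Cn3ccnc3)cc2)cc1`: 238 nM
compound 2, `O=C(c1ccc(Cn2ccnc2)cc1)c1ccc(-c2ccccc2)cc1`: 2530 nM

In an assay on microsomes from placenta for inhibition of Aromatase (Homo sapiens), using NADPH, with stated times of 5 min and 3 h, in the presence of a further agent that is not named here (on this read-out higher numbers stand for weaker inhibition and lower numbers for stronger inhibition), compound 2 stands highest of the two numbers, and compound 1 gives 238 nM. Among the compounds with values here, the single measured step is an 11-fold higher number from compound 1 to compound 2 (1.03 log units; beyond the scatter), a large one, and it came from putting phenyl in place of methoxy on an aromatic carbon.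

Compound 3, `O=C(c1ccc(O)cc1)c1ccc(Cn2ccnc2)cc1`, is not yet measured. Its change from compound 2 is hydroxy in place of phenyl on an aromatic carbon. Within the data shown here, that change undoes the phenyl of compound 2, so the only step bearing on it is the one just described; no step tells how hydroxy compares with methoxy here. The expectation is therefore a large fall in the number, roughly reversing the measured step, with extra uncertainty because compound 1 at 238 nM is the closest guide. The expected step is an 8.4-fold lower number from compound 2 to compound 3 (0.93 log units; beyond the scatter). Compound 3 is estimated at 300 nM, in the range 90 nM to 1000 nM.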

Compound 3, half-maximal inhibitory concentration: 1100 nM
Compound 3: the middle estimate sits 3.7-fold (0.56 log units) below what was measured; measured number outside the range, above it.
By their numbers in this assay, from the lowest: compound 1; then compound 3; then compound 2.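

In this assay, the swap at this position, para to a large group, gives a 2.3-fold lower number from compound 2 to compound 3 (0.36 log units; beyond the scatter), so losing the phenyl lowers the number far less than the step between compound 1 and compound 2 alone would suggest. Hydroxy and methoxy also prove not to be interchangeable here: hydrogen in place of methyl on the oxygen gives a 4.6-fold higher number from compound 1 to compound 3 (0.66 log units; beyond the scatter), which places compound 3 between the other two and leaves compound 1 with the lowest number. No measurement at hand gives a reason for either step.

On these data alone, it remains open how an ethoxy group, an amine or a single fluorine atom at this position would compare with methoxy and hydroxy. These three compounds also cannot tell whether the same order of methoxy, hydroxy and phenyl would hold on a different core.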